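Solubility notes on the shared core: amine-side variations

This account rests on a few compounds, and the source may have more. Where it says the series, first, only, none or still open, it means among the compounds named here.

Measured in a physicochemical assay for solubility, read by HPLC, using the shake flask method, measured as kinetic solubility, with a stated time of 2 h, at pH 7.4; a higher number here means a more soluble compound, a lower number a less soluble compound:
compound 1 `Cc1cc(NCc2ccncc2)n2nc(C)c(-c3ccccc3)c2n1`: 134000 nM
compound 2 `Cc1cc(NCCCc2ccccn2)n2nc(C)c(-c3ccccc3)c2n1`: 5900 nM
compound 3 `Cc1cc(NCc2cccs2)n2nc(C)c(-c3ccccc3)c2n1`: < 5000 nM

Compound 1 gives 134000 nM in this assay. Compound 2 gives 5900 nM, a step of a 23-fold lower number from compound 1 to compound 2 (1.36 log units; beyond the scatter). For compound 3 the result is only a limit, < 5000 nM, a reading at the limit of < 5000 nM in this assay, at which 1 of the 3 values shown sits. Compound 3 therefore stands at the low end of what has been measured here, with an at least 26-fold lower number from compound 1 to compound 3 (1.42 log units; beyond the scatter) and an at least 1.1-fold lower number from compound 2 to compound 3 (0.07 log units; that floor lies within the scatter).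

The next member, compound 4 `CCN1CCCC1CNc1cc(C)nc2c(-c3ccccc3)c(C)nn12`, differs from compound 3 by 1-ethylpyrrolidin-2-yl in place of thiophen-2-yl on a saturated chain carbon bound to a nitrogen on an aromatic ring. Within the data shown here, no measured step contains the entering group, so the only steps that bear on it are those ending at compound 3. Both of those were downward into the limit, and the thiophen-2-yl group that leaves here is the group they introduced. Removing it is expected to move the number upward, though how far is uncertain. Compound 4 is estimated at 40000 nM, between 5000 nM and 200000 nM, meaning an expected step of an at least 8.0-fold higher number from compound 3 to compound 4 (0.90 log units; beyond the scatter).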

Compound 4, solubility: 172000 nM
Estimate against measurement, compound 4: 4.3-fold (0.63 log units) below, within the range that was stated.
By their numbers in this assay, from the lowest: compound 2; then compounds 1 and 4 (each within the scatter of the next). At a limit, below all of these: compound 3.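

At this position, on a saturated chain carbon bound to a nitrogen on an aromatic ring, 1-ethylpyrrolidin-2-yl is the only non-aromatic ring shown, and in this assay it gives an at least 34-fold higher number from compound 3 to compound 4 (1.53 log units; beyond the scatter). Compound 3 holds only a limit, so that step is a floor: the limit of < 5000 nM in this assay, at which 1 of the 4 values shown sits. The same group gives a 29-fold higher number from compound 2 to compound 4 (1.46 log units; beyond the scatter), while a 1.3-fold higher number from compound 1 to compound 4 (0.11 log units; within the scatter) leaves 1-ethylpyrrolidin-2-yl and pyridin-4-yl indistinguishable, so an aromatic ring at this position is not required for a reading at the level of compound 1.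

The compounds shown leave open whether this step belongs to the ring nitrogen, the ethyl group or the saturated ring itself. A cyclopentyl ring or an open-chain diethylamino group at the same place would help separate these.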